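Swapping a butoxy group for chloro on the aromatic ring

The source may hold more compounds than are shown below. What is called first, only, known or untested is meant among the compounds shown, and "the series" means these compounds.

Three close relatives sharing one core have been measured in an assay for inhibition of Dihydrofolate reductase (Gallus gallus); a lower number here means a stronger inhibitor, a higher number a weaker inhibitor. Compound 1 `Cc1ccccc1Cc1cnc(N)nc1N` gives 29500 nM. Compound 2 `CCCCOc1ccccc1Cc1cnc(N)nc1N` gives 8710 nM, the strongest of the three. Compound 3 `Nc1ncc(Cc2ccccc2F)c(N)n1` gives 43700 nM. The step of a 3.4-fold lower number from compound 1 to compound 2 (0.53 log units; beyond the scatter) and the step of a 5.0-fold higher number from compound 2 to compound 3 (0.70 log units; beyond the scatter) both point the same way: the butoxy group goes with the lowest number. Compound 4 `Nc1ncc(Cc2ccccc2Cl)c(N)n1` has not yet been measured; it differs from compound 2 by chloro in place of butoxy on an aromatic carbon. The closest guide is the step from butoxy to fluoro, a single halogen atom, so a weakening of similar size is expected. Compound 4 is expected to give about 30000 nM, within 12000 nM to 80000 nM. That estimate means an expected step of a 3.4-fold higher number from compound 2 to compound 4 (0.54 log units; beyond the scatter).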

Compound 4, inhibition constant: 17400 nM
For compound 4 the middle estimate is 1.7-fold (0.24 log units) above the measured one; low and high end bracket the measured number.
By their numbers in this assay, from the lowest: compounds 2, 4, 1 and 3 (each within the scatter of the next, the first and the last beyond it).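

Replacing butoxy with a lone chloro in this assay gives a 2.0-fold higher number from compound 2 to compound 4 (0.30 log units; within the scatter) and so no clear loss at this position. Against methyl, chloro gives a 1.7-fold lower number from compound 1 to compound 4 (0.23 log units; within the scatter) as well, which leaves compound 4 level with both compound 1 and compound 2, even though those two lie beyond the scatter of each other. The halogens do part, since a 2.5-fold lower number from compound 3 to compound 4 (0.40 log units; beyond the scatter) shows that this position tells chloro from fluoro. No measurement here explains that gap. Going by these compounds, whether bromo, an amine or a carboxylic acid would fit this position stays open.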